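A few compounds are considered here, and "the series" means these few. Any claim that something is new, unique, unknown or untested is made for them only; others in the source may bear on it.

Compound 1 `O=C(NNc1ccccc1Cl)c1ccc(NS(=O)(=O)c2cnc(O)nc2O)cc1`: 3340 nM
Compound 2 `O=C(NNc1ccc(F)cc1)c1cccc(NS(=O)(=O)c2cnc(O)nc2O)c1`: > 20000 nM (a limit of the assay)
Compound 3 `O=C(NNc1ccccc1F)c1ccccc1NS(=O)(=O)c1cnc(O)nc1O`: 9610 nM

In a functional assay on A549 cells (Homo sapiens) for antiproliferative activity, read by MTT assay, with a stated time of 24 h (a higher number here means a weaker inhibitor, a lower number a stronger inhibitor), compound 1 has the lower of the two actual numbers, and the gap to compound 3 lies beyond the scatter. The entry for compound 2 is a limit, not a number.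

Compound 4 `O=C(NNC(=O)c1cccc(Cl)c1)c1ccc(NS(=O)(=O)c2cnc(O)nc2O)cc1` differs from compound 1 by one change: (3-chlorophenyl)carbonyl in place of 2-chlorophenyl on an amine nitrogen with (3-chlorophenyl)carbonyl in place of 2-chlorophenyl on an amine nitrogen. Among the compounds with values here, no measured pair shows such a change, so the expectation is loose. Within the data shown here, with compound 1 at 3340 nM as the lowest number so far, a moderate move toward a higher number in this assay is expected. The estimated step is a 2.1-fold higher number from compound 1 to compound 4 (0.32 log units; beyond the scatter) overall. For compound 4 the expected value is 7000 nM within an estimated range of 2000 nM to 20000 nM in this assay.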

Compound 4, half-maximal inhibitory concentration: 2290 nM
Compound 4: the middle estimate sits 3.1-fold (0.49 log units) above what was measured, within the range that was stated.
By their numbers in this assay, from the lowest: compounds 4 and 1 (each within the scatter of the next); then compound 3. At a limit, above all of these: compound 2.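

In this assay, within the data shown here, the first comparison in one place gives a 1.5-fold lower number from compound 1 to compound 4 (0.16 log units; within the scatter) for (3-chlorophenyl)carbonyl in place of 2-chlorophenyl on an amine nitrogen. At this position, then, the added carbonyl and the different chlorine naming come with no difference beyond the scatter, so this exchange is tolerated in this assay. Nothing measured here offers a reason for that result.

The carbonyl and the chlorine difference arrive together, so their contributions cannot be separated. On these data alone, how a (2-chlorophenyl)carbonyl or a plain acetyl group would read on this nitrogen remains open.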